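Swapping Methyl for Fluoro on the Outer Phenyl Ring

The source may hold more compounds than are shown below. What is called first, only, known or untested is meant among the compounds shown, and "the series" means these compounds.

Measured compounds:
compound 1, `CN(C)C(=O)c1cc2cnc(Nc3ccc(NC(=O)C4(C(=O)Nc5ccc(Br)cc5)CC4)cc3)nc2n1C1CCCC1`: 21.1%
compound 2, `CN(C)C(=O)c1cc2cnc(Nc3ccc(NC(=O)C4(C(=O)Nc5cccc(C(F)(F)F)c5)CC4)cc3)nc2n1C1CCCC1`: 9.7%
compound 3, `Cc1cccc(NC(=O)C2(C(=O)Nc3ccc(Nc4ncc5cc(C(=O)N(C)C)n(C6CCCC6)c5n4)cc3)CC2)c1`: 45.7%

The three measured compounds share one core and differ only in the aromatic group on the outer amide nitrogen. In a functional assay on T47D cells (Homo sapiens) for inhibition, read by CCK-8 assay, with a stated time of 72 h, tested at 1 uM (on this read-out higher numbers stand for more inhibition of growth at the one concentration tested and lower numbers for less inhibition of growth), compound 3 stands highest of the three; the step of a number 24.6 percentage points higher from compound 1 to compound 3 (beyond the scatter) and the step of a number 36 percentage points higher from compound 2 to compound 3 (beyond the scatter) both lie beyond the scatter, so compound 3 is the most active of the set. The step of a number 11.4 percentage points lower from compound 1 to compound 2 (beyond the scatter) shows the two halogenated analogues sitting lower still, with the trifluoromethyl compound lowest.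

Compound 4, `CN(C)C(=O)c1cc2cnc(Nc3ccc(NC(=O)C4(C(=O)Nc5cccc(F)c5)CC4)cc3)nc2n1C1CCCC1`, is not yet measured. It differs from compound 3 as follows: fluoro in place of methyl on an aromatic carbon. Among the measured steps, a number 36 percentage points higher from compound 2 to compound 3 (beyond the scatter) bears most directly on this, since it also exchanges a group on this same aromatic carbon, and a number 24.6 percentage points higher from compound 1 to compound 3 (beyond the scatter) concerns the same ring position in a looser sense. Both point the same way: the methyl-bearing compound 3 is higher than any substitute tried so far. A fluoro substituent is expected to move the number downward, by a modest amount, a number 19.7 percentage points lower from compound 3 to compound 4 (beyond the scatter). Compound 4 is therefore estimated at 26%, within a range from 10% to 44%.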

Compound 4, percent growth inhibition at one concentration: -3.2%
The estimate for compound 4 lay 29.2 percentage points above the measured number; measured number outside the range, below it.
By their numbers in this assay, from the lowest: compound 4; then compound 2; then compound 1; then compound 3.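

In this assay the exchange of one heavy atom on this ring carbon gives a number 48.9 percentage points lower from compound 3 to compound 4 (beyond the scatter) and this is the largest step in the set, even though neither methyl nor fluoro carries a hydrogen-bond donor or acceptor. Methyl now stands apart from both fluorine-bearing groups at this carbon, but the order among those two is not what the earlier compounds could show: fluoro lies under trifluoromethyl, with a number 12.9 percentage points lower from compound 2 to compound 4 (beyond the scatter) and the 3-fluorophenyl compound also lies under the 4-bromophenyl one, with a number 24.3 percentage points lower from compound 1 to compound 4 (beyond the scatter) which leaves it lowest of the four. Among these compounds, nothing available here explains why so small a change moves the number so far.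

Going by these compounds, what an ethyl, a methoxy or an amine would give on this same carbon remains open, so it cannot yet be said whether methyl is a lone high point or one member of a wider group that does well here. Also open, on these data alone, is whether methyl keeps its number on another carbon of the ring, since the 4-bromophenyl compound changes both the group and its place.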